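The compounds below may be only part of what the source reports. "The series", "measured", "known", "first", "only" and "open" are said of these compounds alone.

Measured in a functional assay on NCI-H460 cells (Homo sapiens); a higher number here means that more compound is needed for the effect, a lower number that less compound is needed:
- compound 1 `COc1cc(OC)c(C2OC(c3ccc(N)c(C)c3)=NN2C(C)=O)cc1OC`: 1000 uM
- compound 2 `COC(=O)N1N=C(c2ccc(N(C)C)cc2)OC1c1cc(OC)c(OC)c(OC)c1`: 106 uM

Of these two numbers, compound 2 has the lower one at 106 uM, so less of it is needed for the effect than of compound 1, and the gap lies beyond the scatter. These two compounds differ in more than one place, so their gap cannot be pinned on any single group.

Compound 3 `COc1cc(C2OC(c3ccc(N(C)C)cc3)=NN2C(=O)CNC(C)=O)cc(OC)c1OC` has not yet been measured. It differs from compound 2 in one place: on a carbonyl carbon whose other neighbours are an amide-type nitrogen in a ring, acetamidomethyl stands in place of methoxy (acetamidomethyl in place of methoxy on a carbonyl carbon). For the measured compounds named here, no measured pair shows this change, so neither direction can be favoured in this assay. The best available anchor is compound 2 at 106 uM. The expected step of a 1.1-fold higher number from compound 2 to compound 3 (0.05 log units; within the scatter) therefore stays within the scatter, and a real move either way remains possible. The estimated value for compound 3 is 120 uM, with an expected range from 35 uM to 420 uM.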

Compound 3, concentration for half-maximal effect: 0.48 uM
Beside the measured number, compound 3's estimate is 250-fold (2.40 log units) above it, outside the stated range (below it).
By their numbers in this assay, from the lowest: compound 3; then compound 2; then compound 1.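

The carbonyl carbon on the amide-type nitrogen in the ring turns out to be a highly sensitive place in this assay: acetamidomethyl in place of methoxy gives a 220-fold lower number from compound 2 to compound 3 (2.34 log units; beyond the scatter). The earlier comparison involved compounds that differ in more than one place, whereas this single swap ties a large change in the number to this position, with acetamidomethyl (5 heavy atoms, 1 hydrogen-bond donor) replacing methoxy (2 heavy atoms, 0 hydrogen-bond donors). No measurement shown here explains why the swap has so large an effect, so the step stands as an observation only.

This one change does not show whether the lower number depends on the amide part of the acetamidomethyl group, on the length of the chain, or on the loss of the methoxy oxygen. On these data alone, a simple aminomethyl group or a longer chain ending in an acetamide at the same carbonyl carbon would help separate these possibilities, and it also remains open whether the same swap would have a similar effect on the core of compound 1.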